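Truncating the amine of compound 1

This account rests on a few compounds, and the source may have more. Where it says the series, first, only, none or still open, it means among the compounds named here.

Measured so far: compound 1 `Cn1c(C2CCCN2)nc2ccccc21`, 18100 nM; compound 2 `CC(C)n1c(C2CCCN2)nc2ccccc21`, 12100 nM.

In a functional assay on HEK-293T cells for agonist activity at trace amine-associated receptor 1 (Homo sapiens), read by BRET and cAMP accumulation (on this read-out higher numbers stand for an effect only at larger amounts of compound and lower numbers for an effect already at smaller amounts), compound 1 gives 18100 nM, the highest of the two numbers. Its nearest neighbour, compound 2, gives 12100 nM, and the step of a 1.5-fold lower number from compound 1 to compound 2 (0.17 log units; within the scatter) lies within the scatter. Compound 3 `Cn1c(CN)nc2ccccc21` differs from compound 1 by aminomethyl in place of pyrrolidin-2-yl on an aromatic carbon. Among the measured compounds shown here, the only measured step changes the group on the aromatic nitrogen and leaves the pyrrolidin-2-yl untouched, so no measured step bears on this change. For compound 3 a weakening beyond the scatter is expected, a 1.9-fold higher number from compound 1 to compound 3 (0.29 log units; within the scatter). The estimate for compound 3 is 35000 nM, with a range from 9000 nM to 150000 nM.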

Compound 3, half-maximal effective concentration: > 100000 nM
Compound 3 gave a limit, no number; the forecaster's own chance of this, stated with the estimate: 35%; at least 2.8-fold (0.45 log units) between middle value and limit.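

The aromatic carbon between two ring nitrogen atoms proves sensitive where the change on the aromatic nitrogen did not: aminomethyl in place of pyrrolidin-2-yl gives an at least 5.5-fold higher number from compound 1 to compound 3 (0.74 log units; beyond the scatter). Compound 3 stands at a limit in this assay, not at a number: the limit of > 100000 nM in this assay, at which 1 of the 3 values shown sits. On this single pair, the pyrrolidin-2-yl group cannot be cut back to aminomethyl without a loss beyond the scatter.

From the compounds shown here alone, whether the loss follows the missing ring or the shorter group stays open. An open-chain aminoethyl or a piperidin-2-yl ring at this carbon would bear on that.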